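The source may report more compounds than this note shows. Statements on the series, on what has been measured and on what is new or still open speak of the compounds shown alone.

Measured so far:
Compound 1 `CCCNC(=O)CC1CCc2cc(OC)c(OC)cc21` — 26.7%
Compound 2 `COc1cc2c(cc1OC)C(CC(=O)N1CCCC1)CC2` — 33.3%

In a functional assay on the whole organism (strain Wistar) for inhibition, with Rattus norvegicus as the target, read by paw edema, with stated times of 60 min and 24 h, at a dose of 100 mg/kg by the oral route (on this read-out lower numbers stand for less inhibition and higher numbers for more inhibition at the one dose given (going by the name of the read-out)), compound 2 gives 33.3%, the higher of the two numbers shown, with compound 1 nearest at 26.7%. The step of a number 6.6 percentage points higher from compound 1 to compound 2 (within the scatter) lies within the scatter, so the two compounds are not told apart by this read-out.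

Compound 3 `COc1cc2c(cc1OC)C(CC(=O)N1CCOCC1)CC2` differs from compound 2 in one place: morpholin-4-yl in place of pyrrolidin-1-yl on a carbonyl carbon. For the measured compounds named here, the only measured step that bears on this change is the earlier exchange of amine on the same carbonyl carbon, a number 6.6 percentage points higher from compound 1 to compound 2 (within the scatter), which stayed within the scatter. On that single step, an exchange of one cyclic amine for another at this position is expected to move the read-out by no more than the scatter.

Compound 3 is therefore estimated to give 30%, with a range from 15% to 45%. The step this estimate means, a number 3.3 percentage points lower from compound 2 to compound 3 (within the scatter), is expected to stay within the scatter.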

Compound 3, a percentage reported as inhibition, in the whole organism at one dose (the size of the read-out at that dose, not a potency): 23.3%
The estimate for compound 3 lay 6.7 percentage points above the measured number; the measured number falls inside the stated range.
By their numbers in this assay, from the lowest: compounds 3, 1 and 2 (each within the scatter of the next).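

In this assay, the exchange of pyrrolidin-1-yl for morpholin-4-yl on the carbonyl carbon (a number 10 percentage points lower from compound 2 to compound 3 (within the scatter)) tests a second cyclic amine at this position, with a six-membered ring carrying one oxygen and one hydrogen-bond acceptor, and the two compounds are not told apart. The open-chain propylamino group and morpholin-4-yl (a number 3.4 percentage points lower from compound 1 to compound 3 (within the scatter)) are not told apart either, so all three amides now stand within the scatter of one another and this read-out shows no preference among these amine groups. No supporting measurement is available to explain these numbers.

On these data alone, whether a piperidin-1-yl group, a dimethylamino group or a carboxylic acid at this position would give a number beyond the scatter remains open. So does how these compounds would compare at other doses, since each number comes from a single dose.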